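Aryl sulfonamide variation on a bromobenzylamine hexyl chain

The compounds below may be only part of what the source reports. "The series", "measured", "known", "first", "only" and "open" are said of these compounds alone.

Measured compounds:
compound 1 `O=[N+]([O-])c1ccc(S(=O)(=O)NCCCCCCNCc2ccc(Br)cc2)cc1` gives 9800 nM in a functional assay on MIA PaCa-2 cells (Homo sapiens) for inhibition, read by MTT assay, with a stated time of 72 h; a higher number here means a weaker inhibitor of growth, a lower number a stronger inhibitor of growth
compound 2 `O=S(=O)(NCCCCCCNCc1ccc(Br)cc1)c1cc(Cl)cc(Cl)c1` gives 12000 nM in this assay
compound 3 `CC(C)c1ccc(S(=O)(=O)NCCCCCCNCc2ccc(Br)cc2)cc1` gives 5730 nM in this assay

Compound 3 has the lowest of the three numbers. Its difference from compound 1 is a 1.7-fold lower number from compound 1 to compound 3 (0.23 log units; within the scatter) and from compound 2 is a 2.1-fold lower number from compound 2 to compound 3 (0.32 log units; beyond the scatter), so only the comparison with compound 2 reaches beyond the scatter; compound 1 and compound 3 cannot be ordered.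

Compound 4 `O=S(=O)(NCCCCCCNCc1ccc(Br)cc1)c1ccc2ccsc2c1` is the next member and is not yet measured in this assay. The change is 1-benzothiophen-6-yl in place of 4-isopropylphenyl on a sulfonyl sulfur. All three measured steps concern the same place, the group on the sulfonyl sulfur: a 1.2-fold higher number from compound 1 to compound 2 (0.09 log units; within the scatter), a 1.7-fold lower number from compound 1 to compound 3 (0.23 log units; within the scatter) and a 2.1-fold lower number from compound 2 to compound 3 (0.32 log units; beyond the scatter). None of them exceeds a modest size, so swapping one aryl group for another at this position has so far moved the number only a little in either direction. Within the data shown here, the entering group is a fused two-ring system rather than a single substituted ring, which none of the measured compounds carries, so the exact direction is uncertain.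

For compound 4 a number close to that of compound 3 is expected, around 6500 nM with a range of 3000 nM to 15000 nM. The expected step is a 1.1-fold higher number from compound 3 to compound 4 (0.05 log units; within the scatter), not beyond the scatter.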

Compound 4, concentration for 50% growth inhibition: 6000 nM
The estimate for compound 4 lay 1.1-fold (0.03 log units) above the measured number; low and high end bracket the measured number.
By their numbers in this assay, from the lowest: compounds 3, 4, 1 and 2 (each within the scatter of the next, the first and the last beyond it).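

In this assay, among these compounds, the 1-benzothiophen-6-yl group, the only fused two-ring group at the sulfonyl sulfur here, cannot be told apart from any of the three single-ring groups (a 1.0-fold higher number from compound 3 to compound 4 (0.02 log units; within the scatter); a 1.6-fold lower number from compound 1 to compound 4 (0.21 log units; within the scatter); a 2.0-fold lower number from compound 2 to compound 4 (0.30 log units; within the scatter)). Among the compounds shown here, compound 4 therefore sits within the scatter of both compound 2 and compound 3, the one pair printed as beyond it, so this position accepts a second aromatic ring and a ring sulfur without a step beyond the scatter. Nothing available bears on why these numbers lie so close.

On these data alone, whether an amine or a carboxylic acid on the aryl ring would move the number further remains open. So does the effect of a longer chain in place of the hexyl chain.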